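The source may hold more compounds than are shown below. What is called first, only, known or untested is meant among the compounds shown, and "the series" means these compounds.

Series so far in a functional assay on DU-145 cells (Homo sapiens) for cytotoxicity, read by MTT assay, with a stated time of 48 h; on this read-out lower numbers stand for stronger inhibition and higher numbers for weaker inhibition
- compound 1 `COc1cc(/C=C/c2ccccc2)c(-c2ccccc2)c(OC)c1OC` gives 82000 nM
- compound 2 `C=C(c1ccc(OC)cc1)c1cc(OC)c(OC)c(OC)c1-c1ccccc1` gives 8000 nM

Compound 2 stands lower of the two, with a gap to compound 1 beyond the scatter. Compound 3 `C=C(c1ccccc1)c1cc(OC)c(OC)c(OC)c1-c1ccccc1` differs from compound 2 by hydrogen in place of methoxy on an aromatic carbon in one place, hydrogen in place of methoxy on an aromatic carbon, para to a large group. Among the compounds with values here, no measured pair shows this change. In this assay a modest move toward a higher number, meaning weaker inhibition, is expected, with a 2.5-fold higher number from compound 2 to compound 3 (0.40 log units; beyond the scatter) as the estimated step. Compound 3 is expected at 20000 nM within an estimated range of 6000 nM to 65000 nM on this read-out.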

Compound 3, half-maximal inhibitory concentration: 36000 nM
Compound 3: middle estimate off by 1.8-fold (0.26 log units), on the low side; low and high end bracket the measured number.
By their numbers in this assay, from the lowest: compound 2; then compound 3; then compound 1.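

In this assay, going from 4-methoxyphenyl to phenyl gives a 4.5-fold higher number from compound 2 to compound 3 (0.65 log units; beyond the scatter) as weaker inhibition, so the methoxy para to a large group counts for something in this series. With 1-phenylethenyl in place of 2-phenylethenyl, the series shows a 2.3-fold lower number from compound 1 to compound 3 (0.36 log units; beyond the scatter) as stronger inhibition, which separates the effect of that change from the methoxy step. Nothing available explains either step. Open, from the compounds shown here alone, is whether an amine or a hydroxyl at the methoxy place would match compound 2. Also open, going by these compounds, is whether methoxy has the same effect on the 2-phenylethenyl compounds.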